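The source may report more compounds than this note shows. Statements on the series, on what has been measured and on what is new or still open speak of the compounds shown alone.

In a functional assay on CHO-K1 cells for antagonist activity at prostaglandin E2 receptor EP1 subtype (Homo sapiens), read by FLIPR (on this read-out higher numbers stand for weaker inhibition and lower numbers for stronger inhibition), compound 1 `Cc1cc(C(=O)O)nn1Cc1cc(Br)ccc1OCc1ccc(Cl)cc1Cl` gives 0.49 nM, compound 2 `Cc1cc(C(=O)O)nn1Cc1cc(Br)ccc1OCc1ccccc1Cl` gives 28.8 nM, and compound 3 `Cc1cc(C(=O)O)nn1Cc1cc(Br)ccc1OCc1cccc(C(F)(F)F)c1` gives 1100 nM. Compound 1 differs from compound 2 by chloro in place of hydrogen on an aromatic carbon, and that single change brought a 59-fold lower number from compound 2 to compound 1 (1.77 log units; beyond the scatter). The difference between the cores of compound 2 and compound 3 is not broken down here. Compound 4 `Cc1cc(C(=O)O)nn1Cc1cc(Br)ccc1OCc1ccc(Cl)c(C(F)(F)F)c1`, not yet measured in this assay, differs from compound 3 by chloro in place of hydrogen on an aromatic carbon. This is the same kind of change as from compound 2 to compound 1, but the surroundings differ: in compound 1 the entering chloro is meta to a chloro group, whereas in compound 4 it is ortho to a trifluoromethyl group, and in both it is para to a large group. Among the compounds with values here, the step of a 59-fold lower number from compound 2 to compound 1 (1.77 log units; beyond the scatter) is the only guide available. A smaller step is expected here, roughly an 11-fold lower number from compound 3 to compound 4 (1.04 log units; beyond the scatter). Compound 4 is therefore estimated at 100 nM, within 20 nM to 500 nM.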

Compound 4, inhibition constant: < 2000 nM
Compound 4: a limit, no number; the forecaster's own chance of this, stated with the estimate: 2%; the middle value does not contradict the limit.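

In this assay, within the data shown here, compound 4 gives < 2000 nM, which is a limit and not a number, so no step from compound 3 to compound 4 can be read. Going by these compounds, what stays open is how far chloro in place of hydrogen, ortho to a trifluoromethyl group, shifts the number.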